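The source may report more compounds than this note shows. Statements on the series, on what has been measured and on what is new or still open speak of the compounds shown alone.

Compound 1 `CCOc1nc(C(C)(C)C)ccc1CNC(=O)C(C)c1ccc(NS(C)(=O)=O)c(F)c1` gives 14.8 nM in an assay on cells for antagonist activity at transient receptor potential cation channel subfamily V member 1 (Homo sapiens), read by FLIPR and calcium flux, with a stated time of 6 min; a higher number here means a weaker inhibitor, a lower number a stronger inhibitor.
Compound 2 `CC(C(=O)NCc1ccc(C(C)(C)C)nc1OC1CCCC1)c1ccc(NS(C)(=O)=O)c(F)c1` gives 1.5 nM in this assay.

Going by the values given here, of these two numbers, compound 1 stands with the higher one, and the single measured step is a 9.9-fold lower number from compound 1 to compound 2 (0.99 log units; beyond the scatter), a cyclopentyl in place of ethyl on an oxygen on an aromatic ring. Compound 3 `CC(C(=O)NCc1ccc(C(C)(C)C)nc1OC1CCCCC1)c1ccc(NS(C)(=O)=O)c(F)c1` differs from compound 1 by cyclohexyl in place of ethyl on an oxygen on an aromatic ring. The step from compound 1 to compound 2 bears directly on this change, so a lower number well beyond the scatter is expected in this assay. Compound 3 is expected to give 2 nM, within a range from 0.6 nM to 7 nM. This estimate means an expected step of a 7.4-fold lower number from compound 1 to compound 3 (0.87 log units; beyond the scatter).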

Compound 3, inhibition constant: 2.5 nM
Compound 3: middle estimate off by 1.3-fold (0.10 log units), on the low side; low and high end bracket the measured number.
By their numbers in this assay, from the lowest: compounds 2 and 3 (each within the scatter of the next); then compound 1.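

In this assay, a second ring on the oxygen repeats the gain over ethyl, with a 5.9-fold lower number from compound 1 to compound 3 (0.77 log units; beyond the scatter), so the lower number is not confined to cyclopentyl. Enlarging that ring to cyclohexyl gives a 1.7-fold higher number from compound 2 to compound 3 (0.22 log units; within the scatter), so these two rings cannot be told apart here. No available evidence accounts for the gain over ethyl. Still open, on these data alone, is how a smaller ring such as cyclopropyl, or an open branched chain such as isopropyl, would compare. So is whether a ring carrying an oxygen, such as tetrahydropyranyl, would keep these numbers.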